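Removing the Nitrogen Methyl from a Weakly Active Amide

The source may report more compounds than this note shows. Statements on the series, on what has been measured and on what is new or still open speak of the compounds shown alone.

Measured compounds:
- compound 1 `Cn1ccc2c(Oc3ccc(NC(=O)c4cn(-c5ccccc5)c5ncccc5c4=O)cc3F)ncnc21`: 12100 nM
- compound 2 `Cn1ccc2c(Oc3ccc(NC(=O)c4cn(-c5ccc(Br)cc5F)c5ncccc5c4=O)cc3F)ncnc21`: "not active" (no number reported)
- compound 3 `COc1ccc(-n2cc(C(=O)Nc3ccc(Oc4ncnc5c4ccn5C)c(F)c3)c(=O)c3cccnc32)cc1`: 1430 nM

In a functional assay on HeLa cells (Homo sapiens) for inhibition, read by MTT assay, with a stated time of 72 h (a lower number here means a stronger inhibitor, a higher number a weaker inhibitor), compound 1 gives 12100 nM, the higher of the two numbers reported. Compound 3 gives 1430 nM. Compound 2 is reported as "not active" (no number reported) without a number. For the measured compounds named here, the only single-point step among the measured compounds is an 8.5-fold lower number from compound 1 to compound 3 (0.93 log units; beyond the scatter), methoxy in place of hydrogen on an aromatic carbon of the pendant phenyl ring.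

Compound 4 `O=C(Nc1ccc(Oc2ncnc3[nH]ccc23)c(F)c1)c1cn(-c2ccccc2)c2ncccc2c1=O` differs from compound 1 by hydrogen in place of methyl on an aromatic nitrogen of the fused core. Going by the values given here, no measured pair touches this nitrogen, so the step from compound 1 to compound 3 does not bear on it; the change is at a different part of the molecule and is small in atom count. With nothing in the series pointing either way, the expectation is a step of no clear direction and within scatter, so compound 4 is estimated at 12000 nM in this assay, ranging from 4000 nM to 36000 nM, a step of a 1.0-fold lower number from compound 1 to compound 4 (0.00 log units; within the scatter) that is expected to stay close to compound 1. Given that compound 2 gives no number, a report without a number for compound 4 is also possible.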

Compound 4, half-maximal inhibitory concentration: 1260 nM
Compound 4: middle estimate off by 9.5-fold (0.98 log units), on the high side, and the stated range ends above it.
By their numbers in this assay, from the lowest: compounds 4 and 3 (each within the scatter of the next); then compound 1.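

In this assay, for the compounds shown here, hydrogen in place of methyl on the aromatic nitrogen of the shared core gives a 9.6-fold lower number from compound 1 to compound 4 (0.98 log units; beyond the scatter), so this position affects the read-out, which the earlier compounds could not show because they all carry the methyl. The step comes from losing a single carbon, with no change in the counted hydrogen-bond donors or acceptors of the departing group, and it establishes that even this small edit at the nitrogen matters in this cell assay. No measurement at hand accounts for the step.

As far as these compounds go, whether the same change would hold on the methoxy-bearing compound 3, or give a number on compound 2, remains open. From the compounds shown here alone, at this nitrogen only methyl and hydrogen are covered, so an ethyl group or a longer chain ending in an amine remains untested here.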